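A few compounds are considered here, and "the series" means these few. Any claim that something is new, unique, unknown or untested is made for them only; others in the source may bear on it.

In a functional assay on SMMC-7721 cells (Homo sapiens) for cytotoxicity, read by MTT assay, with a stated time of 24 h (a lower number here means a stronger inhibitor, a higher number a weaker inhibitor), three compounds sharing one core have been measured, and they differ only in a single group on an aromatic ring. Compound 1 (`O=C1/C(=C/c2cccnc2)CN(S(=O)(=O)c2ccc(C(F)(F)F)cc2)C/C1=C\c1ccccc1C(F)(F)F`) carries trifluoromethyl and gives 1730 nM as its value. Compound 2 (`O=C1/C(=C/c2cccnc2)CN(S(=O)(=O)c2ccc(F)cc2)C/C1=C\c1ccccc1C(F)(F)F`) carries fluoro and gives 6390 nM as its value. Compound 3 (`O=C1/C(=C/c2cccnc2)CN(S(=O)(=O)c2ccc(Br)cc2)C/C1=C\c1ccccc1C(F)(F)F`) carries bromo and gives 5760 nM as its value, which places it level with compound 2 and on a higher number than compound 1. Replacing trifluoromethyl gives a 3.7-fold higher number from compound 1 to compound 2 (0.57 log units; beyond the scatter) in one case and a 3.3-fold higher number from compound 1 to compound 3 (0.52 log units; beyond the scatter) in the other, while exchanging fluoro for bromo gives a 1.1-fold lower number from compound 2 to compound 3 (0.05 log units; within the scatter) and so separates nothing.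

Compound 4 (`CC(=O)Nc1ccc(S(=O)(=O)N2C/C(=C\c3cccnc3)C(=O)/C(=C/c3ccccc3C(F)(F)F)C2)cc1`) keeps everything in compound 3 except that one group (acetamido in place of bromo on an aromatic carbon): acetamido in place of bromo on an aromatic carbon. Among the compounds with values here, no measured compound carries acetamido, so these steps give only a rough guide to size and none to direction. The expectation rests on compound 3 with 5760 nM as the starting value and on the largest measured step, which is a 3.7-fold higher number from compound 1 to compound 2 (0.57 log units; beyond the scatter) in size. In this assay no step beyond the scatter is therefore expected, though a modest one either way would not surprise. The estimated change is small (a 1.0-fold lower number from compound 3 to compound 4 (0.02 log units; within the scatter)). For compound 4 the expected value is 5500 nM with an estimated range from 2500 nM to 12000 nM as its bounds.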

Compound 4, half-maximal inhibitory concentration: 9830 nM
The estimate for compound 4 lay 1.8-fold (0.25 log units) below the measured number; the measured number falls inside the stated range.
By their numbers in this assay, from the lowest: compound 1; then compounds 3, 2 and 4 (each within the scatter of the next).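

In this assay, putting acetamido at this place on the ring, with its four heavy atoms, hydrogen-bond donor and hydrogen-bond acceptor, gives a result that cannot be separated from bromo, which has one heavy atom and neither feature: the exchange gives a 1.7-fold higher number from compound 3 to compound 4 (0.23 log units; within the scatter), while the exchange from fluoro gives a 1.5-fold higher number from compound 2 to compound 4 (0.19 log units; within the scatter). Compound 2, compound 3 and compound 4 therefore form one group in this assay, even though the substituents differ much more than fluoro and bromo did, whereas trifluoromethyl remains apart, with a 5.7-fold higher number from compound 1 to compound 4 (0.75 log units; beyond the scatter). The compounds shown offer no measurement that explains why trifluoromethyl stands apart from the other three groups.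

On these data alone, it remains open whether an amine, a carboxylic acid or a longer chain such as propionamido at this place would fall with compound 1 or with the other three compounds. Within the data shown here, only this one group varies here, so it is also open whether the same picture would hold if the trifluoromethyl on the other aromatic ring of the shared core were replaced by a chlorine atom.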